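A few compounds are considered here, and "the series" means these few. Any claim that something is new, unique, unknown or untested is made for them only; others in the source may bear on it.

Two compounds that share the same fused two-ring core carrying a phenyl group have been tested in an ADME assay on THP-1 cells (Homo sapiens) for cytotoxicity, read by MTT assay, with a stated time of 72 h; a higher number here means that more compound is needed for the effect, a lower number that less compound is needed. Compound 1 `Cc1ccncc1-c1ccc2[nH]c(=O)nc(-c3ccccc3)c2c1` reaches only the limit of the test, so that compound 1 gives > 50000 nM as a limit and not a number. Compound 2 `O=c1nc(-c2ccccc2)c2cc(-c3ccccc3F)ccc2[nH]1` gives 50000 nM. The step of a number no higher from compound 1 to compound 2 (the limit leaves the size open) cannot be sized because one end of it sits at the limit described by the limit of > 50000 nM in this assay, at which 1 of the 2 values shown sits. Compound 2 therefore stands at the only actual number shown in this assay, while the other value is a limit. Compound 3 `O=c1nc(-c2ccccc2)c2cc(-c3ccc(F)cc3)ccc2[nH]1` has not yet been measured; it differs from compound 2 by 4-fluorophenyl in place of 2-fluorophenyl on an aromatic carbon. For the measured compounds named here, the single measured step that bears on this change gives no readable size, so the only guide is that both measured compounds sit at or near the same weak level. The step of no change at the digits printed from compound 2 to compound 3 (within the scatter) is therefore expected to be none beyond the scatter. Compound 3 is estimated to give 50000 nM in this assay, within a range from 25000 nM to 100000 nM, and may well come back as a limit.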

Compound 3, half-maximal effective concentration: > 50000 nM
Compound 3: only a limit was reported (the forecaster's own chance of this, stated with the estimate: 60%); the middle value sits exactly at the limit.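

In this assay, for the compounds shown here, 4-fluorophenyl in place of 2-fluorophenyl gives a number no lower from compound 2 to compound 3 (the limit leaves the size open); this step and the one linking compound 1 with compound 3 cannot be read as sizes. What is new is that two compounds with the same atoms, joined differently, now sit at this position, and moving the fluorine on the ring does not bring the effect in at a lower concentration than in compound 2. With a third aromatic group at this carbon, the series mostly rests at the ceiling of the test, so any real difference among these groups stays hidden: the limit of > 50000 nM in this assay, at which 2 of the 3 values shown sit.

From the compounds shown here alone, all three compounds carry a six-membered aromatic ring at this carbon, so it remains open whether a different kind of group there, such as an amine, a carboxylic acid or a longer chain, would give a clear number well under the ceiling. Also open, going by these compounds, is how 3-fluorophenyl would behave, and whether the phenyl group on the shared core has any bearing on the effect.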